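Dimethylcarbamoyl for cyano: expected cytotoxicity of compound 3

This account rests on a few compounds, and the source may have more. Where it says the series, first, only, none or still open, it means among the compounds named here.

Compound 1 `Fc1cccc(F)c1Cn1c(-c2c(F)cccc2F)nc2c(Br)cccc21` and compound 2 `N#Cc1cccc2c1nc(-c1c(F)cccc1F)n2Cc1c(F)cccc1F` share one core and differ in a single group. In a toxicity assay on CCRF-CEM cells (Homo sapiens) for cytotoxicity (a lower number here means that less compound is tolerated, a higher number that more compound is tolerated), compound 1 gives 24.5 uM and compound 2 gives 26.7 uM so the two stand level within the scatter of each other. Among the measured compounds shown here, the only measured step, a 1.1-fold higher number from compound 1 to compound 2 (0.04 log units; within the scatter) for cyano in place of bromo on an aromatic carbon, lies within the scatter.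

Compound 3 `CN(C)C(=O)c1cccc2c1nc(-c1c(F)cccc1F)n2Cc1c(F)cccc1F` carries dimethylcarbamoyl in place of cyano on an aromatic carbon at the same place on the shared core. For the measured compounds named here, no measured compound carries dimethylcarbamoyl, so the entering group itself remains untested and the range has to stay wide. Going by the values given here, the step of a 1.1-fold higher number from compound 1 to compound 2 (0.04 log units; within the scatter) is the only guide at this place, and on that evidence no step beyond the scatter is expected. The estimated change a 1.1-fold higher number from compound 2 to compound 3 (0.05 log units; within the scatter) therefore stays within the scatter, and the data do not settle its direction. In this assay compound 3 is expected at 30 uM within an estimated range of 14 uM to 70 uM until it is measured.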

Compound 3, half-maximal toxic concentration: 80.1 uM
Estimate against measurement, compound 3: 2.7-fold (0.43 log units) below, outside the stated range (above it).
By their numbers in this assay, from the lowest: compounds 1 and 2 (each within the scatter of the next); then compound 3.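

In this assay, the place on the aromatic carbon, ortho to a fused ring, does respond to the group it carries: a 3.0-fold higher number from compound 2 to compound 3 (0.48 log units; beyond the scatter) and a 3.3-fold higher number from compound 1 to compound 3 (0.51 log units; beyond the scatter), both beyond the scatter, whereas bromo and cyano could not be told apart, with a 1.1-fold higher number from compound 1 to compound 2 (0.04 log units; within the scatter). The counts for cyano and dimethylcarbamoyl match in hydrogen-bond donors, hydrogen-bond acceptors and net charge, so these counts do not separate the two groups, while heavy-atom count and bond type outside aromatic rings do differ. Nothing available here accounts for the higher number of compound 3.

The compounds shown leave open whether the shift belongs to the carbonyl or to the two methyl groups on the amide nitrogen, and an unsubstituted carboxamide or a carboxylic acid at the same place would bear on that. Also open, on these data alone, is whether an amine or an amide with longer chains on its nitrogen would carry the number further, or return it to the level of compound 1 and compound 2.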